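This account rests on a few compounds, and the source may have more. Where it says the series, first, only, none or still open, it means among the compounds named here.

Measured compounds:
Compound 1 `N#CC1=C(N)Oc2c(N)cc3nc4ccccc4nc3c2C12C(=O)N(Cc1cnnn1-c1cccc(Br)c1)c1ccccc12` — in a functional assay on HCT-116 cells (Homo sapiens) for antiproliferative activity, read by MTT assay, with a stated time of 48 h (a lower number here means a stronger inhibitor, a higher number a weaker inhibitor), compound 1 gives 26100 nM.
Compound 2 `CCOc1ccc(-n2nncc2CN2C(=O)C3(C(C#N)=C(N)Oc4c(N)cc5nc6ccccc6nc5c43)c3ccccc32)cc1` — in this assay compound 2 gives only a limit, > 50000 nM.
Compound 3 `N#CC1=C(N)Oc2c(N)cc3nc4ccccc4nc3c2C12C(=O)N(Cc1cnnn1-c1c(Cl)cc(Cl)cc1Cl)c1ccccc12` — in this assay compound 3 gives 12100 nM.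

Compound 3 holds the lowest of the two numbers; the other shown value is a limit (the limit of > 50000 nM in this assay, at which 1 of the 3 values shown sits). Compound 4 `COc1cc(-n2nncc2CN2C(=O)C3(C(C#N)=C(N)Oc4c(N)cc5nc6ccccc6nc5c43)c3ccccc32)c(OC)cc1Cl` differs from compound 3 by 4-chloro-2,5-dimethoxyphenyl in place of 2,4,6-trichlorophenyl on an aromatic nitrogen. Both measured steps bear on this, as each swaps the ring on the aromatic nitrogen: a 2.2-fold lower number from compound 1 to compound 3 (0.33 log units; beyond the scatter) and an at least 4.1-fold lower number from compound 2 to compound 3 (0.61 log units; beyond the scatter). The halogen-rich ring gave the lowest number, the alkoxy-bearing ring a limit. Compound 4 carries two methoxy groups beside one chlorine, so the number is expected to move back up modestly, a 2.1-fold higher number from compound 3 to compound 4 (0.32 log units; beyond the scatter). Compound 4 is estimated at 25000 nM, range 10000 nM to 60000 nM.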

Compound 4, half-maximal inhibitory concentration: > 50000 nM
Compound 4: no number, only a limit (the forecaster's own chance of this, stated with the estimate: 25%); middle value at least 2.0-fold (0.30 log units) away from the limit.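

Retaining one chlorine on the ring does not keep the number near compound 3: 4-chloro-2,5-dimethoxyphenyl gives an at least 4.1-fold higher number from compound 3 to compound 4 (0.61 log units; beyond the scatter) in this assay, so a halogen on this ring is not enough on its own. The comparison with compound 1 gives an at least 1.9-fold higher number from compound 1 to compound 4 (0.28 log units; that floor lies within the scatter), whose floor stays within the scatter, and the step between compound 2 and compound 4 cannot be read. Compound 4, like compound 2, gives only a limit: the limit of > 50000 nM in this assay, at which 2 of the 4 values shown sit.

On these data alone, how far past that limit either compound lies remains open. Also open, as far as these compounds go, is whether an amine or a carboxylic acid in place of the methoxy groups would bring the number back toward compound 3.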